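A few compounds are considered here, and "the series" means these few. Any claim that something is new, unique, unknown or untested is made for them only; others in the source may bear on it.

Working notes on the triazene series in a functional assay on HeLa cells (Homo sapiens) for cytotoxicity, read by MTT assay, with a stated time of 72 h; a lower number here means a stronger inhibitor, a higher number a weaker inhibitor. Compound 1 `CC(=O)Oc1ccc(/C=C/C(=O)N(/N=N/c2ccc(Cl)c(C(F)(F)F)c2)c2ccc(Cl)c(C(F)(F)F)c2)cc1OC(C)=O` gives 43000 nM. Compound 2 `O=[N+]([O-])c1ccc(/N=N/Nc2ccc([N+](=O)[O-])cc2Br)c(Br)c1` gives 940 nM. Compound 3 `O=C(c1ccccc1F)N(/N=N/c1ccc([N+](=O)[O-])cc1Cl)c1ccc([N+](=O)[O-])cc1Cl` gives 2350 nM, the second highest of the three numbers: compound 2 lies below it by a margin beyond the scatter, and compound 1 lies far above it, also beyond the scatter.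

Compound 4 `COC(=O)N(/N=N/c1ccc([N+](=O)[O-])cc1Cl)c1ccc([N+](=O)[O-])cc1Cl` differs from compound 3 in one place, (methoxy in place of 2-fluorophenyl on a carbonyl carbon), that is, methoxy in place of 2-fluorophenyl on a carbonyl carbon. Among the measured compounds shown here, no measured pair in the set shows the effect of this change, so the size of the step from compound 3 to compound 4 is uncertain; a small weakening, close to the scatter, is expected. Compound 4 is estimated at 3500 nM, within 1200 nM to 10000 nM, an expected step of a 1.5-fold higher number from compound 3 to compound 4 (0.17 log units; within the scatter).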

Compound 4, half-maximal inhibitory concentration: 980 nM
Beside the measured number, compound 4's estimate is 3.6-fold (0.55 log units) above it; the whole stated range lies above it.
By their numbers in this assay, from the lowest: compounds 2 and 4 (each within the scatter of the next); then compound 3; then compound 1.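

In this assay, this position, on a carbonyl carbon whose other neighbour is the amide-type nitrogen, keeps its activity without an aromatic ring: methoxy in place of 2-fluorophenyl gives a 2.4-fold lower number from compound 3 to compound 4 (0.38 log units; beyond the scatter), a modest step in the stronger direction. The 2-fluorophenyl group is therefore not required here for activity in the compounds shown. Nothing available accounts for the size or direction of this step.

With a single pair at this position, the loss of the ring and the entry of the oxygen cannot be told apart. Ethoxy, benzyloxy or an amine on the same carbonyl carbon would bear on that question.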